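Methoxy added to a core with only limit readings

The compounds below may be only part of what the source reports. "The series", "measured", "known", "first", "only" and "open" are said of these compounds alone.

In an ADME assay on cells (Hepatocyte, Homo sapiens) for cytotoxicity, read by MTT assay, with a stated time of 48 h (on this read-out higher numbers stand for lower toxicity in this test and lower numbers for higher toxicity in this test), compound 1 (`COc1cc(NC(C)CCCNC(=O)c2c(C)[n+]([O-])c3ccccc3[n+]2[O-])c2ncccc2c1`) gives only a limit, > 212000 nM. Compound 2 (`COc1cc(NC(C)CCCNC(=O)c2c(C)[n+]([O-])c3ccc(Cl)cc3[n+]2[O-])c2ncccc2c1`) also gives only a limit, > 198000 nM. Among the compounds with values here, the single measured change, chloro in place of hydrogen on an aromatic carbon, is a step that the two limits leave unreadable from compound 1 to compound 2, so it offers no size to carry over. Compound 3 (`COc1cc(NC(C)CCCNC(=O)c2c(C)[n+]([O-])c3ccc(OC)cc3[n+]2[O-])c2ncccc2c1`) has methoxy in place of hydrogen on an aromatic carbon. In this assay, no change beyond the scatter is expected, and the estimated step is an at least 1.0-fold lower number from compound 1 to compound 3 (0.02 log units; that floor lies within the scatter). For compound 3 the expected value is 200000 nM, with an estimated range from 100000 nM to 400000 nM, and a further limit is the likeliest report.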

Compound 3, half-maximal cytotoxic concentration: > 203000 nM
Compound 3 gave a limit, no number; the forecaster's own chance of this, stated with the estimate: 85%; at least 1.0-fold (0.00 log units) between middle value and limit.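

No step can be read among compound 1, compound 2 and compound 3, since each gives only a limit in this assay. The compounds shown leave open whether methoxy or chloro in place of hydrogen changes the half-maximal cytotoxic concentration at all.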